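Ester variation on the shared core: bromostyryl replaces dinitrophenyl

A few compounds are considered here, and "the series" means these few. Any claim that something is new, unique, unknown or untested is made for them only; others in the source may bear on it.

Compound 1 `COc1ccc(C(=O)OCC2Oc3ccc([C@H]4Oc5cc(O)cc(O)c5C(=O)[C@@H]4O)cc3OC2c2ccc(O)c(OC)c2)cc1` and compound 2 `COc1cc(C2Oc3cc([C@H]4Oc5cc(O)cc(O)c5C(=O)[C@@H]4O)ccc3OC2COC(=O)c2cc([N+](=O)[O-])cc([N+](=O)[O-])c2)ccc1O` share a core and differ only in the ester group. For the measured compounds named here, in a functional assay, read by spectrophotometry, with a stated time of 30 min (on this read-out lower numbers stand for an effect already at smaller amounts and higher numbers for an effect only at larger amounts of compound), compound 1 gives 73300 nM, while compound 2 gives 205000 nM, so compound 2 stands as the higher of the two numbers, with a 2.8-fold higher number from compound 1 to compound 2 (0.45 log units; beyond the scatter) as the one measured step so far. Compound 3 `COc1cc(C2Oc3cc([C@H]4Oc5cc(O)cc(O)c5C(=O)[C@@H]4O)ccc3OC2COC(=O)/C=C/c2ccc(Br)cc2)ccc1O` is the next member: 2-(4-bromophenyl)ethenyl in place of 3,5-dinitrophenyl on a carbonyl carbon. Going by the values given here, the only step that bears on this change is the one just named, which moved the number upward when 3,5-dinitrophenyl entered; removing that group again, now for 2-(4-bromophenyl)ethenyl, is therefore expected to bring the number back toward the value of compound 1, a modest downward step rather than none. For compound 3 the expected step is a 2.3-fold lower number from compound 2 to compound 3 (0.36 log units; beyond the scatter), and compound 3 is estimated at 90000 nM, in the range 35000 nM to 230000 nM.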

Compound 3, half-maximal effective concentration: 88900 nM
Compound 3: middle estimate off by 1.0-fold (0.01 log units), on the high side, within the range that was stated.
By their numbers in this assay, from the lowest: compounds 1 and 3 (each within the scatter of the next); then compound 2.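

Working from the ester position on the carbonyl carbon in this assay, 2-(4-bromophenyl)ethenyl in place of 3,5-dinitrophenyl gives a 2.3-fold lower number from compound 2 to compound 3 (0.36 log units; beyond the scatter) and so shows that the number of compound 2 is not shared by every other ester group tried. 2-(4-bromophenyl)ethenyl in place of 4-methoxyphenyl gives a 1.2-fold higher number from compound 1 to compound 3 (0.08 log units; within the scatter) and so two differently built groups read alike here, leaving 3,5-dinitrophenyl alone apart among the three. No measurement at hand gives a cause for this difference.

The compounds shown do not separate the contribution of the ethenyl link from that of the bromine, since no 4-bromophenyl group sits directly on the carbonyl carbon. Also open, from the compounds shown here alone, is how a longer saturated carbon chain, or an ester group carrying an amine or a carboxylic acid, would read at this position.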